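Replacing the Cyclopropyl Ketone of Compound 1 with a Diethylamide

The compounds below may be only part of what the source reports. "The series", "measured", "known", "first", "only" and "open" are said of these compounds alone.

Measured compounds:
compound 1, `CC1=C(C(=O)C2CC2)C(c2ccco2)NC(=O)N1`, 7%
compound 2, `CC1=C(C(=O)C2CC2)C(c2cccs2)NC(=O)N1`, 15%
compound 3, `CC1=C(C(=O)C2CC2)C(c2ccsc2)NC(=O)N1`, 1%

Three compounds sharing one core were measured in an assay on membranes from HeLa cells for displacement of a labelled ligand from adenosine receptor A3 (Homo sapiens), read by scintillation counting, with a stated time of 180 min, tested at 1 uM; a lower number here means less inhibition, a higher number more inhibition at the concentration tested (going by the name of the read-out). Compound 1 stands second highest of the three numbers; its nearest neighbour is compound 3, a number 6 percentage points lower from compound 1 to compound 3 (within the scatter), and its furthest is compound 2, a number 8 percentage points higher from compound 1 to compound 2 (within the scatter). Among the measured compounds shown here, the only step beyond the scatter is a number 14 percentage points lower from compound 2 to compound 3 (beyond the scatter). Compound 4, `CCN(CC)C(=O)C1=C(C)NC(=O)NC1c1ccco1`, has not been measured. It differs from compound 1 by diethylamino in place of cyclopropyl on a carbonyl carbon. For the measured compounds named here, none of the measured steps touches the carbonyl substituent; all three vary only the aromatic ring on the saturated ring carbon, so no measured step bears on this change. Since every measured number sits low and the two steps from compound 1 lie within the scatter, compound 4 is expected to give a number near that of compound 1, with no change at the digits printed from compound 1 to compound 4 (within the scatter) foreseen as no step beyond the scatter in this assay. Compound 4 is therefore estimated at 7%, within a range from -4% to 18%.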

Compound 4, a percentage reported as inhibition, at one concentration (the size of the read-out at that concentration, not a potency): 19%
For compound 4 the middle estimate is 12 percentage points below the measured one; measured number outside the range, above it.
By their numbers in this assay, from the lowest: compounds 3, 1, 2 and 4 (each within the scatter of the next, the first and the last beyond it).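

In this assay, diethylamino in place of cyclopropyl on a carbonyl carbon, with the furan-2-yl group held fixed, gives a number 12 percentage points higher from compound 1 to compound 4 (beyond the scatter) as the result. This is the first change shown at the carbonyl substituent, and it shows that this position can move the number, whereas the earlier steps varied only the aromatic ring on the saturated ring carbon. Nothing measured here accounts for the step.

A dimethylamino group, a piperidine ring or an ethyl ketone would help separate the part played by the entering nitrogen from that of the two ethyl chains, but none stands among these compounds. Also open, on these data alone, is whether diethylamino gives a similar step with thiophen-2-yl or thiophen-3-yl on the saturated ring carbon.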